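The source may hold more compounds than are shown below. What is called first, only, known or untested is meant among the compounds shown, and "the series" means these compounds.

Working notes on the series. Of the compounds shown here, three have been read in a functional assay on LM7 cells (Homo sapiens) for antiproliferative activity, read by MTT assay, with a stated time of 72 h; a lower number here means a stronger inhibitor, a higher number a weaker inhibitor. Compound 1 `CCOC(=O)c1cc(=O)c2cc(CSC(=S)N(C)c3ccccc3)ccc2o1` reaches only a limit of the assay, > 25000 nM, in this assay. Compound 3 `O=c1cc(CSC(=S)N2CCCCC2)oc2ccccc12` likewise returns only a limit, > 25000 nM, in this assay. Among the compounds with values here, compound 2 `O=c1c(CSC(=S)N2CCN(c3ccccc3)CC2)coc2ccccc12` is the one member with a number, 2900 nM in this assay. The other two values are limits, as the limit of > 25000 nM in this assay, at which 2 of the 3 values shown sit, records. Within the data shown here, no pair of measured compounds differs in a single place, so no measured step is available within the three.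

Compound 4 `CN1CCN(C(=S)SCc2coc3ccccc3c2=O)CC1` is not yet measured in this assay. Against compound 2 the change is methyl in place of phenyl on an amine nitrogen in a ring. Among the measured compounds shown here, no measured pair isolates this change. The closest comparison is compound 3, which has no phenyl on its ring nitrogen and gives only a limit, > 25000 nM, in this assay. Compound 2, which carries the phenyl, gives 2900 nM. On that basis a step beyond the scatter towards weaker inhibition is expected, estimated as a 5.2-fold higher number from compound 2 to compound 4 (0.71 log units; beyond the scatter). Compound 4 is expected near 15000 nM in this assay, within 4000 nM to 40000 nM, with a real chance that only a limit is returned.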

Compound 4, half-maximal inhibitory concentration: 17600 nM
Compound 4: middle estimate off by 1.2-fold (0.07 log units), on the low side; the measured number falls inside the stated range.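

In this assay, within the data shown here, methyl in place of phenyl on an amine nitrogen in a ring gives a 6.1-fold higher number from compound 2 to compound 4 (0.78 log units; beyond the scatter) and this is the first step read between two numbers on a single change. It shows that this nitrogen, three ring bonds from the ring nitrogen that carries the side chain, is a place where the group matters to the read-out, and that the phenyl-bearing compound 2 is the stronger member of this pair. The step is modest, and compound 4 still returns a number and not a limit, so within this pair the change from phenyl to methyl weakens the compound without taking it to the end of the measurable range.

Going by these compounds, how an ethyl, a benzyl, a pyridyl or a plain hydrogen on that nitrogen would read stays open, so the step cannot yet be assigned to the size of the group or to the aromatic ring it removes. Steps to compound 1 and compound 3 cannot be read because their values are limits: the limit of > 25000 nM in this assay, at which 2 of the 4 values shown sit.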